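Swapping a Nitrile for Trifluoromethoxy on a Stable Scaffold

The source may hold more compounds than are shown below. What is called first, only, known or untested is meant among the compounds shown, and "the series" means these compounds.

Of the compounds shown here, three sharing one core have been tested in an ADME assay (liver, Mus musculus, strain CD1) for metabolic stability, using microsomes, with a stated time of 1 h; on this read-out higher numbers stand for a more stable compound and lower numbers for a less stable compound. Compound 1 `O=[N+]([O-])c1cn2c(n1)OC[C@@H](OCc1c(Cl)cc(-c3ccc(OC(F)(F)F)cc3)cc1Cl)C2` gives 93%. Compound 2 `O=[N+]([O-])c1cn2c(n1)OC[C@@H](OCc1ccc(-c3ccc(OC(F)(F)F)cc3)c(F)c1)C2` gives 91% in this assay. Compound 3 `N#Cc1cc(-c2ccc(OC(F)(F)F)cc2)ccc1CO[C@@H]1COc2nc([N+](=O)[O-])cn2C1` gives 88% in this assay. All three numbers sit within the usual scatter of one another, so none of the three can be called more or less stable than the others; each of them remains largely intact over the hour of the test.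

Compound 4 `O=[N+]([O-])c1cn2c(n1)OC[C@@H](OCc1ccc(-c3ccc(OC(F)(F)F)cc3)cc1OC(F)(F)F)C2` has not yet been measured. It differs from compound 3 in one place: trifluoromethoxy in place of cyano on an aromatic carbon. Going by the values given here, no measured pair in this set shows what such a swap does, so the expectation rests only on the fact that every measured compound, whatever group sits at this position, has stayed near the top of the scale.

Compound 4 is therefore expected to give about 89% in this assay, with a range from 76% to 97%. The expected step of a number 1 percentage points higher from compound 3 to compound 4 (within the scatter) is none beyond the scatter, in no clear direction.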

Compound 4, percent of the compound remaining: 100%
Beside the measured number, compound 4's estimate is 11 percentage points below it; measured number outside the range, above it.
By their numbers in this assay, from the lowest: compounds 3, 2, 1 and 4 (each within the scatter of the next, the first and the last beyond it).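

In this assay, going by these compounds alone, the swap gives a number 12 percentage points higher from compound 3 to compound 4 (beyond the scatter), the first difference in this set that clears the usual scatter and the only one measured between compounds that differ in a single place. This shows that the aromatic carbon ortho to a large group and meta to a 4-(trifluoromethoxy)phenyl group accepts trifluoromethoxy in place of cyano with no loss of stability, even though the entering group has 5 heavy atoms and the leaving group has 2, and that a change here can move the number by a modest but readable amount. The two groups have the same counts of hydrogen-bond donors and acceptors, but nothing measured here explains the rise.

On these data alone, what an amine, a carboxylic acid or a longer chain would do on this same aromatic carbon remains open. Also open, as far as these compounds go, is whether trifluoromethoxy in place of cyano would give a similar step on a compound with different groups elsewhere, and with compound 4 at 100% the read-out has no room left to show any further gain.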